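Meta-substituted arylpiperazine sulfonamides at the adenosine A3 receptor

The source may report more compounds than this note shows. Statements on the series, on what has been measured and on what is new or still open speak of the compounds shown alone.

Compound 1 `CCCn1c(=O)[nH]c2nc(-c3ccc(S(=O)(=O)N4CCN(c5ccc(Cl)cc5F)CC4)cc3)[nH]c2c1=O` gives > 1000 nM in an assay on CHO cells for displacement of a labelled ligand from adenosine receptor A3 (Homo sapiens), read by scintillation counting, with a stated time of 45 min, in the presence of a further agent that is not named here; on this read-out lower numbers stand for stronger inhibition and higher numbers for weaker inhibition; this is a limit of the assay.
Compound 2 `CCCn1c(=O)[nH]c2nc(-c3ccc(S(=O)(=O)N4CCN(Cc5cccc(C)c5)CC4)cc3)[nH]c2c1=O` gives > 1000 nM in this assay; this too is a limit.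
Compound 3 `CCCn1c(=O)[nH]c2nc(-c3ccc(S(=O)(=O)N4CCN(c5cccc(Cl)c5)CC4)cc3)[nH]c2c1=O` gives 53.5 nM in this assay.

Compound 2 stands at the limit of this assay, where two of the three values sit (the limit of > 1000 nM in this assay, at which 2 of the 3 values shown sit), so its step to compound 1 is not readable (a step that the two limits leave unreadable from compound 1 to compound 2). From compound 2 the change to compound 4 `CCCn1c(=O)[nH]c2nc(-c3ccc(S(=O)(=O)N4CCN(c5cccc(Br)c5)CC4)cc3)[nH]c2c1=O` is 3-bromophenyl in place of 3-methylbenzyl on an amine nitrogen in a ring. The measured step that bears on it is the one to the related 3-chlorophenyl compound, an at least 18-fold lower number from compound 2 to compound 3 (1.27 log units; beyond the scatter), a large drop from the limit to a readable number. Since 3-bromophenyl differs from 3-chlorophenyl only in the halogen, a step of similar size and direction is expected, an at least 16-fold lower number from compound 2 to compound 4 (1.22 log units; beyond the scatter). Compound 4 is therefore estimated at 60 nM, within a range of 20 nM to 200 nM, in this assay.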

Compound 4, inhibition constant: > 1000 nM
Compound 4 was reported as a limit; the forecaster's own chance of this, stated with the estimate: 10%; at least 16-fold (1.22 log units) between middle value and limit.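

Bromo in place of chloro on an aromatic carbon is no neutral exchange at this position: it gives an at least 18-fold higher number from compound 3 to compound 4 (1.27 log units; beyond the scatter) in this assay. The earlier compounds shown here set the 3-chlorophenyl group apart from 4-chloro-2-fluorophenyl and 3-methylbenzyl, and compound 4 now shows that this does not extend to 3-bromophenyl, so a change of the halogen alone is enough to lose a readable number. Compound 3 is left as the only compound with a readable number, and the steps among compound 1, compound 2 and compound 4 cannot be read, since all three values are limits: the limit of > 1000 nM in this assay, at which 3 of the 4 values shown sit.

Going by these compounds, how a 3-fluorophenyl, a 3-methylphenyl or an unsubstituted phenyl group would fall on this ring nitrogen remains open. Also open, on these data alone, is how far compound 1, compound 2 and compound 4 lie from one another beyond their shared limit.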